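The source may hold more compounds than are shown below. What is called first, only, known or untested is meant among the compounds shown, and "the series" means these compounds.

Measured compounds in an assay on HEK293 cells for positive allosteric modulation of metabotropic glutamate receptor 3 (Rattus norvegicus), read by thallium flux, with a stated time of 2.5 min; a lower number here means a smaller maximal response, a higher number a larger maximal response:

Compound 1, `Cc1c(OCCCCOc2ccc(C(=O)C(C)C)c(O)c2C)cccc1C(=O)O`, gives 27.1%.
Compound 2, `CCC(=O)c1ccc(OCCCCOc2cccc(C(=O)O)c2C)c(C)c1O`, gives 16.3%.
Compound 3, `Cc1cc(C(=O)O)ccc1OCCCCOc1ccc(C(=O)C(C)C)c(O)c1C`, gives 25.2%.

Compound 1 and compound 2 share a core and differ only at the ketone side chain: hydrogen in place of methyl on a saturated chain carbon bound to a carbonyl carbon and a saturated chain carbon. This change gives a number 10.8 percentage points lower from compound 1 to compound 2 (beyond the scatter), a drop that exceeds the usual scatter of this assay.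

Compound 3 is built from the same atoms as compound 1, joined differently; the difference between the two cores is not broken down here. In this assay compound 3 and compound 1 lie within the scatter of each other, so no order between them can be claimed, and compound 3 also sits within the scatter of compound 2.

Compound 4, `CCC(=O)c1ccc(OCCCCOc2ccc(C(=O)O)cc2C)c(C)c1O`, has not yet been measured. It stands to compound 3 as compound 2 stands to compound 1: hydrogen in place of methyl on a saturated chain carbon bound to a carbonyl carbon and a saturated chain carbon. The place of the change is described in the same words in both pairs, so it is the same change made on the core of compound 3 instead of the core of compound 1.

Because compound 1 to compound 2 gave a number 10.8 percentage points lower from compound 1 to compound 2 (beyond the scatter), the step from compound 3 to compound 4 is expected to be of a similar size, about a number 10.7 percentage points lower from compound 3 to compound 4 (beyond the scatter). This rests on a single measured pair, so the expectation is loosely held. Compound 4 is accordingly estimated to reach 14.5% in this assay, with a plausible range from 6% to 24%.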

Compound 4, largest response reached (reported as percent of maximum), in percent of the reference or control that the assay uses: 22.7%
The estimate for compound 4 lay 8.2 percentage points below the measured number, and the stated range covers the measured number.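

Swapping isopropyl for ethyl on the ketone, the same change as before but now made on the core of compound 3, gives in this assay a number 2.5 percentage points lower from compound 3 to compound 4 (within the scatter) and so leaves no step that can be told from repeated measurement on this core. Set beside the step on the core of compound 1, this result does not separate the two cores: the same change on two cores in this assay, a number 10.8 percentage points lower (beyond the scatter) from compound 1 to compound 2 and a number 2.5 percentage points lower (within the scatter) from compound 3 to compound 4, 8.3 percentage points apart, within the scatter of two such steps. The two pairs therefore show neither that the change acts differently on the two cores nor that it acts alike, and the clear drop seen on the core of compound 1 cannot be taken as a rule that carries over to the core of compound 3.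

On these data alone, all four compounds carry either the isopropylcarbonyl or the propanoyl group, so it stays open how the largest response would follow other ketone side chains, such as an acetyl or a cyclopropylcarbonyl group, on either core. Also open, as far as these compounds go, is what an amide or a tetrazole in place of the carboxylic acid, or a longer chain between the two ether oxygens, would do to that response.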